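The compounds below may be only part of what the source reports. "The series", "measured", "known", "first", "only" and "open" are said of these compounds alone.

Measured so far in a functional assay on the whole organism (strain Kunming) with Mus musculus as the target, with a stated time of 0.5 h, at a dose of 300 mg/kg by the intraperitoneal route; on this read-out higher numbers stand for a weaker effect at the one dose given and lower numbers for a stronger effect:
compound 1 `COc1ccccc1/C=C/C(=O)OC/C=C/c1cc(OC)c(OC)cc1OC` — 100%
compound 2 `COc1cc(OC)c(OC)cc1/C=C/COC(=O)/C=C/c1ccccc1Cl` — 100%
compound 3 `COc1ccc(/C=C/C(=O)OC/C=C/c2cc(OC)c(OC)cc2OC)cc1` — 100%

The three values lie together: no change at the digits printed from compound 1 to compound 2 (within the scatter), no change at the digits printed from compound 1 to compound 3 (within the scatter) and no change at the digits printed from compound 2 to compound 3 (within the scatter). Compound 1 and compound 2 differ by chloro in place of methoxy on an aromatic carbon, a change that left this assay unmoved. The cores of compound 1 and compound 3 differ by 4-methoxyphenyl in place of 2-methoxyphenyl on a double-bonded chain carbon bound to a double-bonded chain carbon, and here too the read-out stayed where it was.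

Compound 4 `COc1cc(OC)c(OC)cc1/C=C/COC(=O)/C=C/c1ccc(Cl)cc1` has not yet been tested. It differs from compound 3 by chloro in place of methoxy on an aromatic carbon. For the measured compounds named here, this is the same kind of change as the one from compound 1 to compound 2, but not the same: in the earlier pair the exchanged group sits ortho to a large group, whereas in compound 3 and compound 4 it sits para to a large group.

Since the earlier exchange gave no change at the digits printed from compound 1 to compound 2 (within the scatter) and all three measured compounds sit level in this assay, the step from compound 3 to compound 4 is expected to be no change at the digits printed from compound 3 to compound 4 (within the scatter). Compound 4 is therefore estimated at 100% in this assay, with the expected range running from 85% to 100%.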

Compound 4, a percentage reported as activity, at one dose (the size of the read-out at that dose, not a potency): 100%
Compound 4: the middle estimate sits on the measured number at the digits printed; low and high end bracket the measured number.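

In this assay, chloro in place of methoxy was now read on a second core, giving no change at the digits printed from compound 3 to compound 4 (within the scatter), and this agrees with the earlier reading of the same exchange: the same change on two cores in this assay, no change at the digits printed (within the scatter) from compound 1 to compound 2 and no change at the digits printed (within the scatter) from compound 3 to compound 4, 0 percentage points apart, within the scatter of two such steps. The two other new steps are equally flat, with no change at the digits printed from compound 2 to compound 4 (within the scatter) and no change at the digits printed from compound 1 to compound 4 (within the scatter), so all four compounds stand level in this assay. The exchange therefore left the read-out unmoved on both cores, but two steps with no measurable size do not show how the exchange would behave on a core where it moved the read-out, and they give no cause for the flatness.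

The aromatic substituents shown are limited to methoxy and chloro, so it remains open whether an amine or a carboxylic acid on that aromatic ring would shift the value in this assay. Equally open, going by these compounds, is whether a longer chain in place of the link within the shared core would shift it.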